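The compounds below may be only part of what the source reports. "The series", "measured", "known", "first", "only" and "open" are said of these compounds alone.

Working notes on the series. Compound 1 `Nc1nc(NCc2cccs2)nc2sc(-c3ccco3)nc12`, compound 2 `Nc1nc(NCc2cccnc2)nc2sc(-c3ccco3)nc12` and compound 3 `Nc1nc(NCc2ccsc2)nc2sc(-c3ccco3)nc12` share one core and differ only in the aromatic ring on a saturated chain carbon bound to a nitrogen on an aromatic ring. In an assay on CHO cells for displacement of a labelled ligand from adenosine receptor A3 (Homo sapiens), read by scintillation counting, with a stated time of 120 min (on this read-out higher numbers stand for weaker inhibition and lower numbers for stronger inhibition), compound 1 gives 6.43 nM, which is the second highest of the three numbers; compound 2 gives 18.2 nM and compound 3 gives 3.14 nM. The step of a 2.8-fold higher number from compound 1 to compound 2 (0.45 log units; beyond the scatter) and the step of a 2.0-fold lower number from compound 1 to compound 3 (0.31 log units; beyond the scatter) show that exchanging this ring moves the read-out in both directions by a modest amount, and the step of a 5.8-fold lower number from compound 2 to compound 3 (0.76 log units; beyond the scatter) spans the whole range seen so far.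

Compound 4 `Nc1nc(NCc2ccco2)nc2sc(-c3ccco3)nc12` is not yet measured in this assay. It differs from compound 1 as follows: furan-2-yl in place of thiophen-2-yl on a saturated chain carbon bound to a nitrogen on an aromatic ring. Going by the values given here, no measured step makes this exact change; the nearest are the steps from compound 1 to compound 2 and to compound 3, both modest. A step in this assay of similar or smaller size is therefore expected, most likely close to no change beyond the scatter, with a slight lean toward a higher number. Compound 4 is estimated at 8.5 nM, between 3 nM and 24 nM, corresponding to an expected step of a 1.3-fold higher number from compound 1 to compound 4 (0.12 log units; within the scatter).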

Compound 4, inhibition constant: 4.72 nM
Compound 4: the middle estimate sits 1.8-fold (0.26 log units) above what was measured, and the stated range covers the measured number.
By their numbers in this assay, from the lowest: compounds 3, 4 and 1 (each within the scatter of the next, the first and the last beyond it); then compound 2.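

In this assay, furan-2-yl in place of thiophen-2-yl gives a 1.4-fold lower number from compound 1 to compound 4 (0.13 log units; within the scatter), and furan-2-yl in place of thiophen-3-yl gives a 1.5-fold higher number from compound 3 to compound 4 (0.18 log units; within the scatter), so at this place on a saturated chain carbon bound to a nitrogen on an aromatic ring, the exchange of sulfur for oxygen in the ring makes no difference that can be read against either thiophene. Furan-2-yl in place of pyridin-3-yl gives a 3.9-fold lower number from compound 2 to compound 4 (0.59 log units; beyond the scatter), which adds a third five-membered ring to the two already beyond the scatter of compound 2, leaving compound 2 as the only compound set apart from the rest of the series, although compounds 1 and 3 also differ from each other beyond the scatter. Nothing on hand accounts for this ranking of the rings.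

From the compounds shown here alone, it remains open whether a plain phenyl ring, or pyridin-2-yl or pyridin-4-yl, would fall with the five-membered rings or with compound 2. Also open, going by these compounds, is how a saturated ring such as tetrahydrofuran-2-yl, or a longer chain carrying the same furan-2-yl, would read in this assay.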